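Series notes: benzylic chloride purines, third analogue pending

The compounds below may be only part of what the source reports. "The series", "measured", "known", "first", "only" and "open" are said of these compounds alone.

The series consists of three measured compounds sharing one core, differing in where the chloromethyl group sits on the benzyl ring, and one compound awaiting measurement. In a functional assay on SN12C cells (Homo sapiens) for cytotoxicity, read by sulforhodamine B assay, with a stated time of 48 h (on this read-out lower numbers stand for stronger inhibition of growth and higher numbers for weaker inhibition of growth), compound 1 `ClCc1ccc(Cn2cnc3c(Cl)ncnc32)cc1` gives 2340 nM. Compound 3 `ClCc1ccccc1Cn1cnc2ncnc(Cl)c21` gives 8510 nM in this assay. Compound 2 `ClCc1cccc(Cn2cnc3ncnc(Cl)c32)c1` gives 20400 nM in this assay, the highest number of the three; the nearest is compound 3, whose number is lower by a margin beyond the scatter, and the furthest is compound 1, whose number is lower still, also beyond the scatter.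

Compound 4 `ClCc1cccc(Cn2cnc3nc(Cl)nc(Cl)c32)c1` differs from compound 2 in one place: chloro in place of hydrogen on an aromatic carbon of the core. Among the measured compounds shown here, no measured pair shows this change, so there is no step from which to read its size or direction. Given that, the expectation for this assay is a step from compound 2 to compound 4 of a 1.7-fold lower number from compound 2 to compound 4 (0.23 log units; within the scatter), toward a somewhat lower number, with a range wide enough to include no change beyond the scatter. Compound 4 is therefore estimated to give 12000 nM in this assay, within a range of 4000 nM to 40000 nM.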

Compound 4, concentration for total growth inhibition: 2750 nM
The estimate for compound 4 lay 4.4-fold (0.64 log units) above the measured number, and the stated range ends above it.
By their numbers in this assay, from the lowest: compounds 1 and 4 (each within the scatter of the next); then compound 3; then compound 2.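

Chloro in place of hydrogen on an aromatic carbon of the core, between two ring nitrogen atoms, gives a 7.4-fold lower number from compound 2 to compound 4 (0.87 log units; beyond the scatter) in this assay, and this is the only step in the series that can be read from a pair differing in one place. It shows that this carbon of the core is not a silent position: a single added chlorine here moves the number toward stronger inhibition of growth, by a margin beyond the scatter, with the chloromethyl group on the benzyl ring left unchanged. No measurement in hand bears on why the number moves in this way.

The compounds shown leave open whether the step depends on chloro itself or would also appear with another group at this carbon, such as an amine, a methyl group or fluoro. They also leave open whether the same change keeps its size and direction when the chloromethyl group sits where it does in compound 1 or compound 3, since a single pair gives one step on one benzyl pattern.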